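The compounds below may be only part of what the source reports. "The series", "measured", "known", "first", "only" and "open" are said of these compounds alone.

Measured compounds:
Compound 1 `O=C(O[C@H]1C[C@H](n2cc(F)c(=O)[nH]c2=O)O[C@@H]1COP(=O)(O)Oc1cccnc1)c1ccccc1`: 2500 nM
Compound 2 `O=C(O[C@H]1C[C@H](n2cc(F)c(=O)[nH]c2=O)O[C@@H]1COP(=O)(O)Oc1ccc2ncccc2c1)c1ccccc1`: 2460 nM
Compound 3 `CCOC(=O)C[n+]1cccc2cc(OP(=O)([O-])OC[C@H]3O[C@@H](n4cc(F)c(=O)[nH]c4=O)C[C@@H]3OC(=O)c3ccccc3)ccc21`: 28900 nM

In a functional assay on Caco-2 cells (Homo sapiens) for cytotoxicity, read by MTT assay, with a stated time of 48 h (on this read-out higher numbers stand for weaker inhibition and lower numbers for stronger inhibition), compound 1 gives 2500 nM, the second highest of the three numbers; compound 2 sits within the scatter of it, while compound 3 stands furthest away with a much higher number. Compound 4 `C[N+]1(C)CCC(OP(=O)([O-])OC[C@H]2O[C@@H](n3cc(F)c(=O)[nH]c3=O)C[C@@H]2OC(=O)c2ccccc2)CC1` is not yet measured. It differs from compound 1 as follows: a group of 12 heavy atoms (7 carbon, 1 nitrogen, 3 oxygen, 1 phosphorus; one six-membered non-aromatic ring with 1 hetero atom) in place of a group of 10 heavy atoms (5 carbon, 1 nitrogen, 3 oxygen, 1 phosphorus; one six-membered aromatic ring with 1 hetero atom), on an oxygen on a saturated carbon. Going by the values given here, the one step that is known, a 1.0-fold lower number from compound 1 to compound 2 (0.01 log units; within the scatter), changed nothing beyond the scatter, but it exchanged one aromatic group for another and so bears only loosely on this change. Among the compounds with values here, no measured step matches the entry of a non-aromatic ring. Compound 4 is therefore expected to give 8000 nM (range 2500 nM to 30000 nM), a step of a 3.2-fold higher number from compound 1 to compound 4 (0.51 log units; beyond the scatter).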

Compound 4, half-maximal inhibitory concentration: 15700 nM
Compound 4: middle estimate off by 2.0-fold (0.29 log units), on the low side, within the range that was stated.
By their numbers in this assay, from the lowest: compounds 2 and 1 (each within the scatter of the next); then compounds 4 and 3 (each within the scatter of the next).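

In this assay, the exchange of one aromatic group for another gave a 1.0-fold lower number from compound 1 to compound 2 (0.01 log units; within the scatter), whereas a six-membered non-aromatic ring in place of the six-membered aromatic ring gives a 6.3-fold higher number from compound 1 to compound 4 (0.80 log units; beyond the scatter). The read-out at this position therefore does respond to the group placed there, once the aromatic ring is gone. No measurement shown accounts for this step. The compounds shown leave open whether the loss of the aromatic ring alone sets its size, or the whole entering group does; a plain cyclohexyl group or an open-chain amine on the same oxygen would bear on this.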